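The source may hold more compounds than are shown below. What is called first, only, known or untested is meant among the compounds shown, and "the series" means these compounds.

The measured compounds in a functional assay on HeLa S3 cells (Homo sapiens) for antiproliferative activity, read by XTT assay, with a stated time of 72 h (a lower number here means a stronger inhibitor, a higher number a weaker inhibitor), are:

compound 1 `COc1ncnc2c1c(I)cn2[C@@H]1O[C@H](CO)[C@@H](O)[C@H]1O`, giving 14300 nM
compound 2 `COc1ncnc2c1c(-c1ccsc1)cn2[C@@H]1O[C@H](CO)[C@@H](O)[C@H]1O`, giving 3350 nM
compound 3 `COc1ncnc2c1c(-c1ccoc1)cn2[C@@H]1O[C@H](CO)[C@@H](O)[C@H]1O`, giving 1790 nM

Compound 2 stands second highest of the three numbers in this assay; its nearest neighbour is compound 3, separated by a 1.9-fold lower number from compound 2 to compound 3 (0.27 log units; within the scatter), and its furthest is compound 1, separated by a 4.3-fold lower number from compound 1 to compound 2 (0.63 log units; beyond the scatter). Compound 4 `CSc1ncnc2c1c(-c1ccsc1)cn2[C@@H]1O[C@H](CO)[C@@H](O)[C@H]1O` differs from compound 2 in one place: methylsulfanyl in place of methoxy on an aromatic carbon. For the measured compounds named here, none of the measured steps touches this methoxy group; the steps of a 4.3-fold lower number from compound 1 to compound 2 (0.63 log units; beyond the scatter) and an 8.0-fold lower number from compound 1 to compound 3 (0.90 log units; beyond the scatter) concern only the group on the other aromatic carbon. With nothing to guide the direction, compound 4 is expected to give a number close to that of compound 2, a step of a 1.0-fold higher number from compound 2 to compound 4 (0.02 log units; within the scatter), so the estimate for compound 4 is 3500 nM with a range from 1200 nM to 10000 nM.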

Compound 4, half-maximal inhibitory concentration: > 20000 nM
Compound 4: a limit, no number; the forecaster's own chance of this, stated with the estimate: 3%; middle value at least 5.7-fold (0.75 log units) away from the limit.
By their numbers in this assay, from the lowest: compounds 3 and 2 (each within the scatter of the next); then compound 1. At a limit, above all of these: compound 4.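

The earlier steps shown here touched only the other aromatic carbon, whereas in this assay this result shows that the methoxy position itself matters: an at least 5.9-fold higher number from compound 2 to compound 4 (0.77 log units; beyond the scatter). The two groups match in heavy-atom, donor and acceptor counts, so that match alone does not preserve the read-out here. Compound 4 gives a limit, not a number: the limit of > 20000 nM in this assay, at which 1 of the 4 values shown sits.

On these data alone, how far compound 4 lies past that limit stays open, as does whether the same change would have a similar effect alongside the furan-3-yl group of compound 3. Also open, as far as these compounds go, is how an amine or a longer chain such as ethoxy would compare with methoxy at this position.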